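Opening a ring: compound 1 to compound 3

The source may hold more compounds than are shown below. What is called first, only, known or untested is meant among the compounds shown, and "the series" means these compounds.

Compound 1 `CC1CCC(Oc2cccc3ccc(N)nc23)C1` is a ligand of an assay on cells with melanin-concentrating hormone receptor 1 (Homo sapiens) as the target, read by radioligand binding; a lower number here means a stronger inhibitor, a higher number a weaker inhibitor. In this assay compound 1 gives 823 nM. Compound 2 `Nc1ccc2cccc(OCCC3CCCCC3)c2n1` is a close relative, and in this assay compound 2 gives 808 nM; the two numbers sit within the usual scatter of each other, so neither stands apart. Compound 3 `CCCC(C)Oc1cccc2ccc(N)nc12` has not been measured. It differs from compound 1 in one place: 1-methylbutyl in place of 3-methylcyclopentyl on an oxygen on an aromatic ring. No measured step of this kind is shown, so the step of a 1.5-fold higher number from compound 1 to compound 3 (0.16 log units; within the scatter) is expected to be small, if anything toward a weaker inhibitor. Compound 3 is therefore estimated at 1200 nM, with a range from 400 nM to 4000 nM.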

Compound 3, half-maximal inhibitory concentration: 105 nM
The estimate for compound 3 lay 11-fold (1.06 log units) above the measured number; measured number outside the range, below it.
By their numbers in this assay, from the lowest: compound 3; then compounds 2 and 1 (each within the scatter of the next).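

Replacing 3-methylcyclopentyl with the open-chain 1-methylbutyl on this oxygen is not a neutral swap in this assay (a 7.8-fold lower number from compound 1 to compound 3 (0.89 log units; beyond the scatter)). The number at this position therefore depends on the shape of the carbon group it carries, and a ring is not needed here for a number this low. Nothing shown gives a reason for this step. Open questions remain about whether the methyl branch of 1-methylbutyl matters, and whether a longer chain or a chain ending in an amine would lower the number further.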